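Shortening the amide chain on a glycosylated cytosine nucleoside

The compounds below may be only part of what the source reports. "The series", "measured", "known", "first", "only" and "open" are said of these compounds alone.

Measured so far:
- compound 1, `CC(C)=CCC(=O)Nc1ccn([C@H]2CC[C@H](O)[C@@H](C)O2)c(=O)n1`, in a functional assay on HCT-116 cells (Homo sapiens) for cytotoxicity, read by sulforhodamine B assay, with a stated time of 24 h; a higher number here means a weaker inhibitor, a lower number a stronger inhibitor: compound 1 gives > 20000 nM, which is a limit of the assay and not a number.
- compound 2, `CCC(C)/C=C/C(=O)Nc1ccn([C@H]2CC[C@H](O[C@H]3O[C@H](C)[C@@H](N(C)C)[C@H](O)[C@H]3O)[C@@H](C)O2)c(=O)n1`: in this assay compound 2 gives 890 nM.
- compound 3, `CC(C)=CC(=O)Nc1ccn([C@H]2C[C@@H](O)[C@H](O)[C@@H](C)O2)c(=O)n1`: in this assay compound 3 gives > 20000 nM, again a limit and not a number.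

Among the measured compounds shown here, compound 2 therefore stands alone as the only compound with a measured number; the other two values sit at the limit of > 20000 nM in this assay, at which 2 of the 3 values shown sit. No step between two measured compounds is shown, so the amide chain itself has not yet been varied on any compound with a number.

Compound 4, `CC(C)CC(=O)Nc1ccn([C@H]2CC[C@H](O[C@H]3O[C@H](C)[C@@H](N(C)C)[C@H](O)[C@H]3O)[C@@H](C)O2)c(=O)n1`, keeps the shared core of compound 2 with its sugar and changes only the acyl chain: a group of 4 heavy atoms (4 carbon; no ring) in place of a group of 6 heavy atoms (6 carbon; no ring), on a carbonyl carbon. The group that leaves carries one double bond outside aromatic rings; isobutyl, which enters, has none and is shorter.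

Without a measured step to lean on, the expected change in this assay is modest to moderate, toward a weaker inhibitor. Compound 4 is estimated at 3000 nM, with a range from 800 nM to 15000 nM. That estimate means a step of a 3.4-fold higher number from compound 2 to compound 4 (0.53 log units; beyond the scatter), expected to go somewhat beyond the scatter.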

Compound 4, half-maximal inhibitory concentration: 2140 nM
The estimate for compound 4 lay 1.4-fold (0.15 log units) above the measured number; the range from low to high includes it.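

Among the compounds shown here, the swap to isobutyl gives the first readable step on the acyl chain in this assay, and it is a 2.4-fold higher number from compound 2 to compound 4 (0.38 log units; beyond the scatter). This shows that the group on this carbonyl carbon does affect the cytotoxicity read-out, although the shorter chain without a double bond gives only a modestly weaker inhibitor, and compound 4 still has a measured value of 2140 nM. The other values are limits and not numbers, so this one step is all that can be read about the chain so far: the limit of > 20000 nM in this assay, at which 2 of the 4 values shown sit.

The step shortens the chain and removes its double bond at the same time, so these compounds cannot show how much each of the two changes contributes. From the compounds shown here alone, it also remains open how this position would respond to a fully saturated chain of the same length as in compound 2, to a longer chain, or to a chain ending in an amine or a carboxylic acid.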